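A few compounds are considered here, and "the series" means these few. Any claim that something is new, unique, unknown or untested is made for them only; others in the source may bear on it.

Compound 2 `Nc1cc(N)c2nc(-c3ccccc3)c(NCc3ccc(F)cc3)nc2c1` gives 2820 nM in a functional assay on SF-268 cells (Homo sapiens) for inhibition, read by sulforhodamine B assay, with a stated time of 48 h (on this read-out lower numbers stand for stronger inhibition of growth and higher numbers for weaker inhibition of growth), the lower of the two numbers shown; compound 1 `COc1ccc(CNc2nc3cc(N)cc(N)c3nc2-c2ccccc2)cc1OC` gives 14800 nM. Within the data shown here, the one measured step, a 5.2-fold lower number from compound 1 to compound 2 (0.72 log units; beyond the scatter), came from a change on the saturated chain carbon bound to a nitrogen on an aromatic ring. Compound 3 `COc1ccc(CNc2nc3cc(N)cc(N)c3nc2-c2ccccc2)cc1` differs from compound 2 by methoxy in place of fluoro on an aromatic carbon. Because a 5.2-fold lower number from compound 1 to compound 2 (0.72 log units; beyond the scatter) lowered the number as methoxy groups left, putting one methoxy back is expected to raise it, by a smaller step, a 2.1-fold higher number from compound 2 to compound 3 (0.33 log units; beyond the scatter). Compound 3 is therefore estimated at 6000 nM, within 2500 nM to 15000 nM.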

Compound 3, concentration for 50% growth inhibition: 9770 nM
Estimate against measurement, compound 3: 1.6-fold (0.21 log units) below, and the stated range covers the measured number.
By their numbers in this assay, from the lowest: compound 2; then compounds 3 and 1 (each within the scatter of the next).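

The step of a 3.5-fold higher number from compound 2 to compound 3 (0.54 log units; beyond the scatter) in this assay shows that fluoro and methoxy are not interchangeable on this aromatic carbon. The step of a 1.5-fold lower number from compound 1 to compound 3 (0.18 log units; within the scatter) removes the other methoxy without a readable change, so the difference between compound 1 and compound 2 seems to lie mainly with the group kept in compound 3 at this place. No measurement shown here explains why fluoro and methoxy differ. Going by these compounds, whether chloro, hydroxyl or an amine at this place would match fluoro or methoxy stays open, and so does the effect of a longer chain in place of methoxy.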